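The compounds below may be only part of what the source reports. "The series", "measured", "known", "first", "only" and "open" are said of these compounds alone.

Measured compounds in a functional assay on AS49-RAW cells (Homo sapiens) for antiproliferative activity, read by sulforhodamine B assay, with a stated time of 48 h; on this read-out lower numbers stand for stronger inhibition and higher numbers for weaker inhibition:
compound 1 `Nc1ccc(S(=O)(=O)Nc2ccnc3cc(C(F)(F)F)ccc23)cc1` gives 29200 nM
compound 2 `N=C(N)NS(=O)(=O)c1ccc(N/C(S)=N\c2ccnc3cc(C(F)(F)F)ccc23)cc1` gives 23900 nM
compound 3 `O=S(=O)(Nc1nccs1)c1ccc(N/C(S)=N\c2ccnc3cc(C(F)(F)F)ccc23)cc1` gives 27200 nM

Compound 3 stands second highest of the three numbers; its nearest neighbour is compound 1, its furthest compound 2, and all three lie within the scatter of one another, so no order among them is claimed. Going by the values given here, the only measured step that touches the sulfonamide nitrogen, a 1.1-fold higher number from compound 2 to compound 3 (0.06 log units; within the scatter), stays within the scatter.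

Compound 4 `COc1ncnc(NS(=O)(=O)c2ccc(N/C(S)=N\c3ccnc4cc(C(F)(F)F)ccc34)cc2)c1OC` has not been measured. It differs from compound 3 by 5,6-dimethoxypyrimidin-4-yl in place of 1,3-thiazol-2-yl on a sulfonamide nitrogen. The bearing step, a 1.1-fold higher number from compound 2 to compound 3 (0.06 log units; within the scatter), showed that exchanging the group on the sulfonamide nitrogen for a five-membered aromatic ring with two hetero atoms left the number within the scatter; nothing measured speaks to a 5,6-dimethoxypyrimidin-4-yl group at this position. The expectation in this assay is therefore a step of no size beyond the scatter, in no particular direction. Compound 4 is estimated at 27000 nM, with a range from 12000 nM to 60000 nM. The step this estimate implies, a 1.0-fold lower number from compound 3 to compound 4 (0.00 log units; within the scatter), is expected to stay within the scatter.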

Compound 4, half-maximal inhibitory concentration: 81800 nM
The estimate for compound 4 lay 3.0-fold (0.48 log units) below the measured number; measured number above the stated range.
By their numbers in this assay, from the lowest: compounds 2, 3 and 1 (each within the scatter of the next); then compound 4.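

In this assay, the group on the sulfonamide nitrogen can move the number: 5,6-dimethoxypyrimidin-4-yl in place of 1,3-thiazol-2-yl gives a modest step toward weaker inhibition (a 3.0-fold higher number from compound 3 to compound 4 (0.48 log units; beyond the scatter)), and the comparison with the no-ring group of compound 2 runs the same way (a 3.4-fold higher number from compound 2 to compound 4 (0.53 log units; beyond the scatter)). The earlier exchange at this nitrogen (a 1.1-fold higher number from compound 2 to compound 3 (0.06 log units; within the scatter)) had stayed within the scatter, so tolerance here does not extend to every group. Nothing measured explains this shift.

Still open, on these data alone, is whether the step follows the six-membered ring or its two methoxy groups, which a plain pyrimidin-4-yl group would separate. Also open, as far as these compounds go, is whether a small acetyl or methyl group on this nitrogen would leave the number level with compound 2 and compound 3 or shift it in either direction.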